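Compound 1 to Compound 4: What the Numbers Suggest

The source may report more compounds than this note shows. Statements on the series, on what has been measured and on what is new or still open speak of the compounds shown alone.

Compound 1 `COc1cccc(/C=C2\CCC/C(=C\c3ccc(Cl)cc3)C2=O)c1OC` is the starting point of this comparison. In a functional assay on HT-1080 cells (Homo sapiens) for cytotoxicity, read by MTT assay, with a stated time of 72 h (a higher number here means a weaker inhibitor, a lower number a stronger inhibitor), compound 1 gives 11100 nM, the lowest of the three numbers in hand. Compound 2 `COc1ccccc1/C=C1\CCC/C(=C\c2cccc(OC)c2OC)C1=O` gives 14100 nM in this assay, and compound 3 `COc1cccc(/C=C2\CCC/C(=C\c3cccc(Cl)c3Cl)C2=O)c1OC` gives 19300 nM. The three differ from one another only in the aryl group on the double-bonded chain carbon bound to a double-bonded ring carbon, and none of the steps among them leaves the scatter: a 1.3-fold higher number from compound 1 to compound 2 (0.10 log units; within the scatter), a 1.7-fold higher number from compound 1 to compound 3 (0.24 log units; within the scatter) and a 1.4-fold higher number from compound 2 to compound 3 (0.14 log units; within the scatter).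

Compound 4 `COc1cc(/C=C2\CCC/C(=C\c3cccc(OC)c3OC)C2=O)ccc1O` has not yet been measured. It differs from compound 1 as follows: 4-hydroxy-3-methoxyphenyl in place of 4-chlorophenyl on a double-bonded chain carbon bound to a double-bonded ring carbon. Of the measured steps, the two that start from compound 1 bear most directly on this change, since each also exchanges the 4-chlorophenyl for another aryl group at the same place, and both stayed within the scatter. For the measured compounds named here, no measured compound carries the 4-hydroxy-3-methoxyphenyl, so the hydrogen-bond donor it brings is untested. On that basis no step beyond the scatter is expected, and compound 4 is estimated to give 13000 nM (range 5000 nM to 35000 nM) in this assay. The step from compound 1 to compound 4 is thus expected to be a 1.2-fold higher number from compound 1 to compound 4 (0.07 log units; within the scatter).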

Compound 4, half-maximal inhibitory concentration: 5900 nM
Compound 4: middle estimate off by 2.2-fold (0.34 log units), on the high side, and the stated range covers the measured number.
By their numbers in this assay, from the lowest: compounds 4, 1, 2 and 3 (each within the scatter of the next, the first and the last beyond it).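

In this assay, for the compounds shown here, the 4-hydroxy-3-methoxyphenyl, on a double-bonded chain carbon bound to a double-bonded ring carbon, is the first aryl group at this place to give steps that leave the scatter, namely a 3.3-fold lower number from compound 3 to compound 4 (0.51 log units; beyond the scatter) and a 2.4-fold lower number from compound 2 to compound 4 (0.38 log units; beyond the scatter), whereas the steps among compounds 1, 2 and 3 all stayed within it. Against compound 1 the same change gives a 1.9-fold lower number from compound 1 to compound 4 (0.27 log units; within the scatter) and stays within the scatter, so compound 4 separates from compounds 2 and 3 but not from compound 1, and it cannot be called the strongest of the four. No measurement at hand accounts for this behaviour of the entering group, which alone among the aryl groups compared here carries a hydrogen-bond donor.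

The compounds shown do not tell whether the hydroxyl or the methoxy of the entering group matters more, and a hydroxyphenyl without the methoxy, or a methoxyphenyl without the hydroxyl, at this same place would separate the two. They also leave open whether a different group there, such as an aminophenyl or a carboxyphenyl, would move the number beyond the scatter from compound 1.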